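The compounds below may be only part of what the source reports. "The series", "measured", "known", "first", "only" and "open" are said of these compounds alone.

Measured compounds:
- compound 1 `O=C(Nc1nc(-c2cccc(C(F)(F)F)c2)cs1)c1ccc([N+](=O)[O-])o1`: 23900 nM
- compound 2 `COc1cccc(-c2csc(NC(=O)c3ccc(N)o3)n2)c1`: "not determined" (no result reported)

Within the data shown here, in an ADME assay on Vero cells (Chlorocebus sabaeus) for cytotoxicity, read by MTT assay, with a stated time of 72 h (on this read-out higher numbers stand for weaker inhibition and lower numbers for stronger inhibition), compound 1 gives 23900 nM, the only number in this set; for compound 2 this assay returned "not determined" (no result reported), so compound 1 stands alone with nothing to rank against. Compound 3 `O=C(Nc1nc(-c2cccc(NC(=O)C3CC3)c2)cs1)c1ccc([N+](=O)[O-])o1` differs from compound 1 by (cyclopropylcarbonyl)amino in place of trifluoromethyl on an aromatic carbon. Among the measured compounds shown here, no measured step between any two compounds exists here, so the size of this change in this assay is unknown. The expected step from compound 1 to compound 3 is a 1.3-fold higher number from compound 1 to compound 3 (0.10 log units; within the scatter), none beyond the scatter. Compound 3 is estimated at 30000 nM, with a range of 10000 nM to 100000 nM.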

Compound 3, half-maximal inhibitory concentration: 35700 nM
Beside the measured number, compound 3's estimate is 1.2-fold (0.08 log units) below it; measured number inside the range.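

At the aromatic carbon carrying trifluoromethyl, the exchange for (cyclopropylcarbonyl)amino gives a 1.5-fold higher number from compound 1 to compound 3 (0.17 log units; within the scatter) in this assay. This first measured step shows that two groups differing in heavy atoms, ring content and hydrogen-bond donors and acceptors read the same within the scatter at this place. No measurement bearing on this result is available.

From the compounds shown here alone, whether an amine or a carboxylic acid at this place would also stay within the scatter remains open. A single step defines no trend for this position.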